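The source may hold more compounds than are shown below. What is called first, only, known or untested is meant among the compounds shown, and "the series" means these compounds.

Working notes on the series. Compound 1 `OCC1CCN(c2nccnc2OC2CN(c3ncc4ccccc4n3)C2)CC1` gives 174000 nM in a physicochemical assay for solubility, in phosphate buffer, at pH 7.4 (on this read-out lower numbers stand for lower solubility and higher numbers for higher solubility), and compound 2 `OCc1cccc(-c2nccnc2OC2CN(c3ccc4ccccc4n3)C2)c1` gives 29000 nM. For compound 3 `c1ccc(-c2nccnc2OC2CN(c3ccc4ccccc4n3)C2)cc1` this assay reports only a limit, < 1000 nM, so compound 3 sits at the floor of the numbers shown (the limit of < 1000 nM in this assay, at which 1 of the 3 values shown sits). Going by the values given here, the one step that reaches compound 3 is an at least 29-fold lower number from compound 2 to compound 3 (1.46 log units; beyond the scatter). Compound 4 `c1ccc2nc(N3CC(Oc4nccnc4-c4ccc5scnc5c4)C3)ccc2c1` carries 1,3-benzothiazol-5-yl in place of phenyl on an aromatic carbon. Among the compounds with values here, no measured step exchanges one aromatic group for another of this kind, so the expectation leans on compound 3 alone: no step beyond the scatter is expected, a step that the limit leaves unreadable from compound 3 to compound 4, with a further limit the most likely outcome. Compound 4 is therefore estimated at 700 nM, within 150 nM to 3000 nM.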

Compound 4, solubility: < 1000 nM
Compound 4: no number, only a limit; the forecaster's own chance of this, stated with the estimate: 65%; the middle value lies beyond the limit too.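

In this assay compound 4 also gives only a limit, < 1000 nM. Placing 1,3-benzothiazol-5-yl where 3-(hydroxymethyl)phenyl stood gives an at least 29-fold lower number from compound 2 to compound 4 (1.46 log units; beyond the scatter). The step between compound 3 and compound 4 cannot be read, and the hydrogen-bond acceptors that 1,3-benzothiazol-5-yl brings do not lift the value off the floor of the numbers shown: the limit of < 1000 nM in this assay, at which 2 of the 4 values shown sit.

Going by these compounds, how far compound 3 and compound 4 lie beyond the limit stays open, so the two groups cannot be ordered. Also open, on these data alone, is whether an amine or a carboxylic acid on the phenyl would keep the value clear of the limit.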